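Amide chain extension: from compound 2 to compound 3

The source may hold more compounds than are shown below. What is called first, only, known or untested is meant among the compounds shown, and "the series" means these compounds.

Of the compounds shown here, two on this core have numbers so far. Compound 1 `Oc1cc(-c2ccccc2)nc2nnnn12` gives 171000 nM in an assay on cells for binding affinity to cyclic GMP-AMP synthase (Homo sapiens), read by surface plasmon resonance; a lower number here means tighter binding, a higher number weaker binding. Compound 2 `CNC(=O)c1cnn2c(O)cc(-c3ccccc3)nc12` gives 78000 nM in this assay; it holds the lower of the two values, and its gap to compound 1 lies beyond the scatter. Compound 3 `O=C(NCCO)c1cnn2c(O)cc(-c3ccccc3)nc12` is not yet measured; it differs from compound 2 by hydroxymethyl in place of hydrogen on a saturated chain carbon bound to an amide-type nitrogen. Among the compounds with values here, no comparable step is known here, so the step from compound 2 to compound 3 is expected to be small, in either direction, and likely within the scatter a 1.1-fold lower number from compound 2 to compound 3 (0.05 log units; within the scatter). Compound 3 is expected at 70000 nM, within 30000 nM to 160000 nM.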

Compound 3, dissociation constant: 12500 nM
Compound 3: the middle estimate sits 5.6-fold (0.75 log units) above what was measured; the whole stated range lies above it.
By their numbers in this assay, from the lowest: compound 3; then compound 2; then compound 1.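

In this assay, the change from methylcarbamoyl to (2-hydroxyethyl)carbamoyl gives a 6.2-fold lower number from compound 2 to compound 3 (0.80 log units; beyond the scatter), the first sign that the saturated chain carbon bound to an amide-type nitrogen responds to substitution. This single step cannot separate the added chain carbon from the added hydroxyl. No supporting measurement bears on why the number falls.

Still open, as far as these compounds go, is whether a plain ethyl chain would give the same step. Also open, from the compounds shown here alone, is whether a longer hydroxyalkyl chain, or an amine or a carboxylic acid in place of the hydroxyl, would keep it.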